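The source may hold more compounds than are shown below. What is called first, only, known or untested is meant among the compounds shown, and "the series" means these compounds.

Measured compounds in an assay on isolated protein for inhibition of leukotriene B4 receptor 1 (Homo sapiens), tested at 10 uM; on this read-out lower numbers stand for less inhibition and higher numbers for more inhibition at the one concentration tested (going by the name of the read-out):
- compound 1 `CSCc1cc(C(C)=O)c(O)cc1OCCCCCCC#N` gives 97%
- compound 2 `C=CCc1cc(C(C)=O)c(O)cc1OCCCCCCCC#N` gives 88%
- compound 3 `CCc1cc(C(C)=O)c(O)cc1OCCCC(C)(C)c1nnn[nH]1` gives 100%

Compound 2 holds the lowest of the three numbers in this assay. Its nearest neighbour is compound 1, whose number lies within the usual scatter of that of compound 2, so no order between these two can be claimed. Its furthest neighbour is compound 3, whose number lies beyond the scatter above that of compound 2. Within the data shown here, no pair of measured compounds differs in one place only, so no measured single-point step is available to lean on.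

Compound 4 `C=CCc1cc(C(C)=O)c(O)cc1OCCCCCC(C)=O` has not yet been measured. It differs from compound 2 as follows: acetyl in place of 2-cyanoethyl on a saturated chain carbon, five bonds along the chain from an oxygen on an aromatic ring. The end of the saturated chain is where the change sits; all three measured compounds carry a chain ending in a nitrile or a tetrazole, and all three give high numbers in this assay.

Among the measured compounds shown here, with no measured step to guide it, the expected step of a number 10 percentage points lower from compound 2 to compound 4 (within the scatter) is small and downward, roughly at the edge of the scatter. Compound 4 is expected to give about 78% in this assay, within a range from 55% to 95%.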

Compound 4, a percentage reported as inhibition, at one concentration (the size of the read-out at that concentration, not a potency): 98%
Compound 4: the middle estimate sits 20 percentage points below what was measured, and the stated range ends below it.
By their numbers in this assay, from the lowest: compounds 2, 1, 4 and 3 (each within the scatter of the next, the first and the last beyond it).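

In this assay, among these compounds, the step of a number 10 percentage points higher from compound 2 to compound 4 (within the scatter) is the only single-place comparison available, and it comes with acetyl in place of 2-cyanoethyl on a saturated chain carbon, five bonds along the chain from an oxygen on an aromatic ring. On the core of compound 2, a nitrile at the chain end is therefore not needed for a high number at this one concentration, since the chain ending in a carbonyl cannot be told apart from it here. No measurement at hand explains why the two chain ends read alike.

From the compounds shown here alone, whether a carboxylic acid or an amine at the chain end, or a longer chain, would hold the number remains open. A read-out at a single concentration also leaves open whether compound 2 and compound 4 would differ in potency.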